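Methoxy on the phenyl of compound 1: working notes

The source may hold more compounds than are shown below. What is called first, only, known or untested is meant among the compounds shown, and "the series" means these compounds.

Measured so far in a functional assay on MCF7 cells (Homo sapiens) for antiproliferative activity; on this read-out lower numbers stand for stronger inhibition and higher numbers for weaker inhibition:
compound 1, `Cc1c(O)ccc2cc(-n3cc(-c4ccccc4)nn3)c(=O)oc12`, 25200 nM
compound 2, `CC(=O)Oc1ccc2cc(-n3cc(-c4ccccc4)nn3)c(=O)oc2c1C`, 40800 nM

Among the compounds with values here, compound 1 gives the lower of the two numbers in this assay, with compound 2 closest; the one step known, a 1.6-fold higher number from compound 1 to compound 2 (0.21 log units; within the scatter), is the acetyl in place of hydrogen on the ring oxygen and stays within the scatter.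

Compound 3, `COc1ccc(-c2cn(-c3cc4ccc(O)c(C)c4oc3=O)nn2)cc1`, differs from compound 1 by methoxy in place of hydrogen on an aromatic carbon.

Within the data shown here, no measured step touches the phenyl, so the acetyl step does not bear directly on this change; it shows only that the one change tried so far left the number within the scatter. With nothing pointing either way, the step from compound 1 to compound 3 in this assay is expected to be small, a 1.1-fold lower number from compound 1 to compound 3 (0.06 log units; within the scatter), in no clear direction. For compound 3 the estimate in this assay is 22000 nM, with a range from 7000 nM to 70000 nM.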

Compound 3, half-maximal inhibitory concentration: > 100000 nM
Compound 3: only a limit was reported (the forecaster's own chance of this, stated with the estimate: 15%); middle value at least 4.5-fold (0.65 log units) away from the limit.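

In this assay, compound 3 is reported only as a limit: the limit of > 100000 nM in this assay, at which 1 of the 3 values shown sits.

The phenyl is therefore not a silent position in this series: methoxy in place of hydrogen on an aromatic carbon, para to a large group, gives an at least 3.9-fold higher number from compound 1 to compound 3 (0.59 log units; beyond the scatter). Within the data shown here, the earlier change on the ring oxygen gave only a 1.6-fold higher number from compound 1 to compound 2 (0.21 log units; within the scatter), so this is the first single change to move the number beyond the scatter, and its full size remains unfixed.

Going by these compounds, it remains open whether this shift belongs to methoxy itself or to any group placed there, which a fluorine, a hydroxyl or an amine in the same place would help to separate. The compounds shown also give no reason for the step and do not tell whether methoxy elsewhere on the phenyl would act the same way.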